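A few compounds are considered here, and "the series" means these few. Any claim that something is new, unique, unknown or untested is made for them only; others in the source may bear on it.

For the measured compounds named here, in a functional assay on NCI-H460 cells (Homo sapiens) for inhibition, read by MTT assay, with a stated time of 24 h, tested at 10 ug/mL (a higher number here means more inhibition of growth at the concentration tested, a lower number less inhibition of growth), compound 1 `CC(=O)SCCC(CCCCC(=O)O)SC(C)=O` gives 6.04% and compound 2 `O=C(CCCCC(S)CCS)Nc1ccccc1` gives 8.37% so the two lie within the scatter of each other, and compound 1 stands level with the only other measured compound. Compound 3 `CC(=O)SCCC(CCCCC(=O)Nc1ccc(Cl)cc1)SC(C)=O` is compound 1 with (4-chlorophenyl)amino in place of hydroxy on a carbonyl carbon and no other change. Going by the values given here, no measured step shows what this change does, so only a modest rise in this assay is expected. The expected step is a number 8 percentage points higher from compound 1 to compound 3 (within the scatter) and it remains an estimate. For compound 3 the estimated value is 14% with an expected range from 3% to 38% at its upper end.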

Compound 3, percent growth inhibition at one concentration: 14.9%
Compound 3: the middle estimate sits 0.9 percentage points below what was measured; low and high end bracket the measured number.
By their numbers in this assay, from the lowest: compounds 1, 2 and 3 (each within the scatter of the next).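

In this assay, for the compounds shown here, (4-chlorophenyl)amino in place of hydroxy on a carbonyl carbon gives a number 8.9 percentage points higher from compound 1 to compound 3 (within the scatter), the first measured step at this position. It shows that this larger group, with its six-membered aromatic ring, can stand here without a step beyond the scatter. Nothing available explains this step. The compounds shown leave open whether a plain phenylamino group, a benzylamino group or a morpholine at this carbonyl carbon would move the number beyond the scatter. They also leave open what the chlorine itself contributes.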